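Acetylation of a Phenol: Cytotoxicity Expected to Stay Flat

The source may report more compounds than this note shows. Statements on the series, on what has been measured and on what is new or still open speak of the compounds shown alone.

Compound 1 `CC(=O)Oc1ccc(O)cc1C[C@]1(C)[C@@H](C)CC[C@]2(C)C(C)=CCC[C@@H]12`, a limit only: > 27300 nM.
Compound 2 `CC(=O)Oc1ccc(O)c(C[C@]2(C)[C@@H](C)CC[C@]3(C)C(C)=CCC[C@@H]23)c1`, a limit only: > 27300 nM.
Compound 3 `C=C1CCC[C@H]2[C@](C)(Cc3cc(O)ccc3OC(C)=O)[C@@H](C)CC[C@]12C`, a limit only: > 27300 nM.

Of the compounds shown here, three have been measured in an ADME assay on CHO-K1 cells (Cricetulus griseus) for cytotoxicity (on this read-out higher numbers stand for weaker inhibition and lower numbers for stronger inhibition), and none of them gives a number. For compound 1 the read-out is a limit of the assay. For compound 2 it is likewise a limit. For compound 3 it is a limit as well. All three sit at the same point, (the limit of > 27300 nM in this assay, at which 3 of the 3 values shown sit), so compound 2 stands exactly where its two companions stand, and no order among the three can be drawn.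

Compound 4 `CC(=O)Oc1ccc(OC(C)=O)c(C[C@]2(C)[C@@H](C)CC[C@]3(C)C(C)=CCC[C@@H]23)c1` has not been measured. It differs from compound 2 by acetyl in place of hydrogen on an oxygen on an aromatic ring. Among the measured compounds shown here, no step between two measured compounds is available to judge this change, and the only guide is that compound 2 and its two companions all rest at the limit (the limit of > 27300 nM in this assay, at which 3 of the 3 values shown sit). The expected step that the limit leaves unreadable from compound 2 to compound 4 is therefore none beyond the usual scatter. Compound 4 is estimated to give 40000 nM, within 20000 nM to 120000 nM, most probably again reported as a limit rather than a number.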

Compound 4, half-maximal inhibitory concentration: > 24400 nM
Compound 4: a limit, no number (the forecaster's own chance of this, stated with the estimate: 85%); the middle value lies beyond the limit too.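

In this assay compound 4 also gives only a limit, so the steps to it from compound 1 and from compound 2 cannot be read. The compounds shown leave open whether acetyl in place of hydrogen on an oxygen on an aromatic ring shifts this read-out at all.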